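Solubility notes on a shared-core quinazoline-free series

The source may report more compounds than this note shows. Statements on the series, on what has been measured and on what is new or still open speak of the compounds shown alone.

Measured compounds:
compound 1 `COc1cc2ncnc(-n3nc(-c4ccccn4)nc3N)c2cc1OCc1ccccc1` 58000 nM
compound 2 `COc1cc2ncnc(-n3nc(-c4ccccn4)nc3N)c2cc1OCCCN1CC(C)OC(C)C1` 8000 nM
compound 3 `COc1cc2ncnc(-n3nc(-c4ccccn4)nc3N)c2cc1OCCCNC(=O)OC(C)(C)C` 2000 nM

In a physicochemical assay for solubility, in phosphate buffer, with a stated time of 18 h, at pH 7.4 (on this read-out higher numbers stand for higher solubility and lower numbers for lower solubility), compound 3 stands lowest of the three numbers. Its nearest neighbour is compound 2 a 4.0-fold lower number from compound 2 to compound 3 (0.60 log units; beyond the scatter), and the widest gap is a 29-fold lower number from compound 1 to compound 3 (1.46 log units; beyond the scatter). The remaining step, a 7.3-fold lower number from compound 1 to compound 2 (0.86 log units; beyond the scatter), also falls at the same end of the chain.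

Compound 4 `COc1cc2ncnc(-n3nc(-c4ccccn4)nc3N)c2cc1OCCCNC(=O)OCC(F)(F)F` is not yet measured. It differs from compound 3 by 2,2,2-trifluoroethyl in place of tert-butyl on an oxygen next to a carbonyl group. None of the three measured steps touches the oxygen next to the carbonyl group; all of them exchange the group bound to the saturated chain carbon or three bonds along the chain. Going by the values given here, there is therefore no direct precedent for this change in this assay, and the expectation is a step no larger than the usual scatter, a 1.3-fold higher number from compound 3 to compound 4 (0.10 log units; within the scatter), in either direction. Compound 4 is estimated at 2500 nM, with a range from 800 nM to 7000 nM.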

Compound 4, solubility: 100 nM
Compound 4: middle estimate off by 25-fold (1.40 log units), on the high side; the measured number lies below the stated range.
By their numbers in this assay, from the lowest: compound 4; then compound 3; then compound 2; then compound 1.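

Working notes on the series: in this assay the group on an oxygen next to a carbonyl group is not a silent place, since 2,2,2-trifluoroethyl in place of tert-butyl gives a 20-fold lower number from compound 3 to compound 4 (1.30 log units; beyond the scatter) and is a large step at a place that no earlier step touched. Compound 4 now stands lowest of the four numbers, with an 80-fold lower number from compound 2 to compound 4 (1.90 log units; beyond the scatter) and a 580-fold lower number from compound 1 to compound 4 (2.76 log units; beyond the scatter) as its steps from the two compounds highest in the series. Nothing available accounts for the size of the change at this oxygen.

The compounds shown do not separate the presence of the fluorine atoms from the loss of tert-butyl, and a plain ethyl group on the same oxygen would divide the two. Also open, as far as these compounds go, is how a group carrying an amine, placed on this oxygen, would read in this assay as a comparison with both compound 3 and compound 4.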